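This account rests on a few compounds, and the source may have more. Where it says the series, first, only, none or still open, it means among the compounds named here.

Compound 1 `COc1cc(OC)c(-c2coc3cc(OCc4ccccc4)ccc3c2=O)cc1OC` gives 9750 nM in a functional assay on HUVEC cells (Homo sapiens) for antiproliferative activity, read by MTT assay, with a stated time of 24 h (a lower number here means a stronger inhibitor, a higher number a weaker inhibitor), as a measured number. In this assay compound 2 `COc1cc(OC)c(-c2coc3cc(OCc4ccc([N+](=O)[O-])cc4)ccc3c2=O)cc1OC` gives > 10000 nM and this is a limit of the assay, not a number. Compound 2 therefore has no exact place on the scale and stands only at the limit of > 10000 nM in this assay, at which 1 of the 2 values shown sits, in the data so far.

Compound 3 `COc1cc(OC)c(-c2coc3cc(OCc4ccc(C#N)cc4)ccc3c2=O)cc1OC` differs from compound 2 in one place, with cyano in place of nitro on an aromatic carbon, para to a large group: cyano in place of nitro on an aromatic carbon is the full count of that change. Among the compounds with values here, no measured step makes this exact swap. The nearest one acts on the same aromatic carbon, where nitro in place of hydrogen gives an at least 1.0-fold higher number from compound 1 to compound 2 (0.01 log units; that floor lies within the scatter) and so shows nothing beyond the scatter.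

On the strength of that single step, no shift beyond the scatter is expected in this assay in either direction. The expected change is a number no higher from compound 2 to compound 3 (the limit leaves the size open) and this rests on very little data. For compound 3 the estimate is 10000 nM with an expected range of 4000 nM to 25000 nM. An outcome given only as a limit would also fit this expectation.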

Compound 3, half-maximal inhibitory concentration: > 10000 nM
Compound 3 ended at the assay's limit; the forecaster's own chance of this, stated with the estimate: 55%; the middle value sits exactly at the limit.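

Cyano in place of hydrogen on this aromatic carbon gives an at least 1.0-fold higher number from compound 1 to compound 3 (0.01 log units; that floor lies within the scatter), so a second group at this position, after nitro, also shows no shift beyond the scatter in this assay. The step from compound 2 to compound 3 joins two limits of the assay and cannot be read, so nothing can be said about the swap of nitro for cyano except that neither compound gives a measured number. The one measured number among the three belongs to compound 1, and the two substituted compounds share the same limit: the limit of > 10000 nM in this assay, at which 2 of the 3 values shown sit.

On these data alone, it stays open how far past that limit compound 2 and compound 3 lie, and so whether the two groups differ at all in this assay. Within the data shown here, it also stays open whether an amine or a carboxylic acid on this same aromatic carbon would give a measured number, and whether that number would lie clearly lower than the one for compound 1.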